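Benzothiazole Amides: Nitro to Trifluoromethyl on Two Cores

The compounds below may be only part of what the source reports. "The series", "measured", "known", "first", "only" and "open" are said of these compounds alone.

Three amides were assessed in a functional assay on MDA-MB-231 cells (Homo sapiens) for antiproliferative activity, read by sulforhodamine B assay; on this read-out lower numbers stand for stronger inhibition of growth and higher numbers for weaker inhibition of growth. Compound 1 `COc1cccc2sc(NC(=O)c3ccc(C(F)(F)F)cc3)nc12` carries a trifluoromethyl group, and compound 2 `COc1cccc2sc(NC(=O)c3ccc([N+](=O)[O-])cc3)nc12` carries a nitro group on the same core. In this assay compound 1 gives only a limit, > 10 ug/mL. In this assay compound 2 likewise gives only a limit, > 10 ug/mL. The change from compound 2 to compound 1, (trifluoromethyl in place of nitro on an aromatic carbon), therefore yields a step that the two limits leave unreadable from compound 2 to compound 1. Compound 3 `COc1ccc2sc(NC(=O)c3ccc([N+](=O)[O-])cc3)nc2c1` has the same atoms as compound 2, joined differently; the difference between the two cores is not broken down here. In this assay compound 3 also gives only a limit, > 10 ug/mL. All three values sit at the limit of > 10 ug/mL in this assay, at which 3 of the 3 values shown sit. Compound 4 `COc1ccc2sc(NC(=O)c3ccc(C(F)(F)F)cc3)nc2c1` has not yet been measured in this assay. It differs from compound 3 by trifluoromethyl in place of nitro on an aromatic carbon, the same change that turns compound 2 into compound 1. The expected step that the limit leaves unreadable from compound 3 to compound 4 rests on the unreadable step that the two limits leave unreadable from compound 2 to compound 1 and on (the limit of > 10 ug/mL in this assay, at which 3 of the 3 values shown sit). Compound 4 is expected to give 15 ug/mL, estimated between 5 ug/mL and 50 ug/mL.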

Compound 4, concentration for 50% growth inhibition: > 10 ug/mL
Compound 4: a limit, no number; the forecaster's own chance of this, stated with the estimate: 80%; the middle value is on the limit's open side.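

The change from nitro to trifluoromethyl between compound 3 and compound 4 gives no readable step in this assay: both values are limits, not numbers. The compounds shown leave open how strongly any of them inhibits growth, and whether the two groups or the two cores differ at all: the limit of > 10 ug/mL in this assay, at which 4 of the 4 values shown sit.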